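Indolylmethyl replacement on the triazole side chain

A few compounds are considered here, and "the series" means these few. Any claim that something is new, unique, unknown or untested is made for them only; others in the source may bear on it.

Measured so far in a functional assay on PC-3 cells (Homo sapiens) for antiproliferative activity, read by MTT assay, with a stated time of 48 h; on this read-out lower numbers stand for stronger inhibition and higher numbers for weaker inhibition:
compound 1 `COc1ccc(CN(C(=O)Cn2cc(COc3cc(=O)oc4ccccc34)nn2)c2cc(OC)c(OC)c(OC)c2)cc1` gives 5140 nM;
compound 2 `COc1ccc(CN(C(=O)Cn2cc(COc3ccccc3)nn2)c2cc(OC)c(OC)c(OC)c2)cc1` gives 45300 nM;
compound 3 `COc1ccc(CN(C(=O)Cn2cc(CSC3=NCCS3)nn2)c2cc(OC)c(OC)c(OC)c2)cc1` gives 16000 nM.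

Compound 2 has the highest number of the three; its nearest neighbour is compound 3, a 2.8-fold lower number from compound 2 to compound 3 (0.45 log units; beyond the scatter), and the furthest is compound 1, an 8.8-fold higher number from compound 1 to compound 2 (0.95 log units; beyond the scatter). Compound 4 `COc1ccc(CN(C(=O)Cn2cc(Cn3ccc4ccccc43)nn2)c2cc(OC)c(OC)c(OC)c2)cc1` differs from compound 2 by 1H-indol-1-yl in place of phenoxy on a saturated chain carbon bound to an aromatic carbon. The two measured steps that change the same group on compound 2 both moved the number down beyond the scatter, as shown by a 2.8-fold lower number from compound 2 to compound 3 (0.45 log units; beyond the scatter) and by the reverse of an 8.8-fold higher number from compound 1 to compound 2 (0.95 log units; beyond the scatter). A lower number is therefore expected for compound 4, probably a modest step, a 3.8-fold lower number from compound 2 to compound 4 (0.58 log units; beyond the scatter). The estimate for compound 4 in this assay is 12000 nM, with a range from 4000 nM to 40000 nM.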

Compound 4, half-maximal inhibitory concentration: 2390 nM
Compound 4: the middle estimate sits 5.0-fold (0.70 log units) above what was measured; measured number outside the range, below it.
By their numbers in this assay, from the lowest: compound 4; then compound 1; then compound 3; then compound 2.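

Among the compounds shown here, on a saturated chain carbon bound to an aromatic carbon, 1H-indol-1-yl, attached through nitrogen, is the first group to give a large step, a 19-fold lower number from compound 2 to compound 4 (1.28 log units; beyond the scatter). It also improves on the other two groups, with a 6.7-fold lower number from compound 3 to compound 4 (0.83 log units; beyond the scatter) and a 2.2-fold lower number from compound 1 to compound 4 (0.33 log units; beyond the scatter), making compound 4 the strongest of the four beyond the scatter. No supporting data bear on why this change has such an effect.

From the compounds shown here alone, it remains open whether a carboxylic acid or methoxy group on the 1H-indol-1-yl would preserve this gain. An amine at the same place, or a longer chain leading to the 1H-indol-1-yl, is also untested in the compounds shown.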